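A few compounds are considered here, and "the series" means these few. Any claim that something is new, unique, unknown or untested is made for them only; others in the source may bear on it.

Measured so far:
- compound 1 `Cn1c(NN)nc(-c2cccc(O)c2O)c(C#N)c1=O`: 31 ug/mL
- compound 2 `Cn1c(NN)nc(-c2ccco2)c(C#N)c1=O`: 78 ug/mL
- compound 3 `Cn1c(NN)nc(-c2ccc(Cl)cc2)c(C#N)c1=O`: 46 ug/mL

All three compounds share one core and differ only in the aromatic group attached to it. In a functional assay on microsomes for inhibition, with a stated time of 1 h (on this read-out lower numbers stand for stronger inhibition and higher numbers for weaker inhibition), compound 1 gives 31 ug/mL, the lowest number of the three. Compound 3 stands nearest with 46 ug/mL, a gap that lies within the usual scatter, so no order between compound 1 and compound 3 can be read from these numbers. Compound 2 gives 78 ug/mL, a gap from compound 1 that lies beyond the scatter.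

The next compound, compound 4 `Cn1c(NN)nc(-c2ccccc2O)c(C#N)c1=O`, is not yet measured. It differs from compound 1 in one place: hydrogen in place of hydroxy on an aromatic carbon. Going by the values given here, no pair of measured compounds differs by such a single change, so no measured step is available to anchor the expectation; the only guide is that compound 3, which carries a chlorine instead of any hydroxy, gives 46 ug/mL and sits within the scatter of compound 1.

Compound 4 is expected to give a somewhat higher number than compound 1, a step of a 1.8-fold higher number from compound 1 to compound 4 (0.25 log units; within the scatter) that may reach just beyond the scatter but is not expected to be large. The estimate for compound 4 in this assay is 55 ug/mL, with a range of 25 ug/mL to 120 ug/mL.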

Compound 4, half-maximal inhibitory concentration: 34 ug/mL
Estimate against measurement, compound 4: 1.6-fold (0.21 log units) above; measured number inside the range.
By their numbers in this assay, from the lowest: compounds 1, 4, 3 and 2 (each within the scatter of the next, the first and the last beyond it).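

Hydrogen in place of hydroxy gives the first single-place comparison in the series: in this assay the step reads a 1.1-fold higher number from compound 1 to compound 4 (0.04 log units; within the scatter) on an aromatic carbon ortho to a hydroxy group and meta to a large group. Going by these compounds alone, at this position, therefore, hydroxy and hydrogen cannot be told apart on this read-out, which the earlier compounds, differing from one another in the whole aromatic group, could not show. The step concerns this one position only and says nothing about the hydroxy group that stays in compound 4, and no measurement on hand accounts for the result.

Going by these compounds, whether an amine, a methoxy group or a carboxylic acid at this position would read any differently remains open. Also open, on these data alone, is what hydrogen in place of the remaining hydroxy of compound 4 would do.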